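Ester to Primary Amide: Little Change Expected

This account rests on a few compounds, and the source may have more. Where it says the series, first, only, none or still open, it means among the compounds named here.

Compound 1, `CC(C)[C@H](C(=O)Nc1ncc(C(F)(F)F)s1)c1ccc(Cl)cc1`: 95%
Compound 2, `CC(C)[C@H](C(=O)Nc1ncc(C#N)s1)c1ccc(Cl)cc1`: 105%
Compound 3, `COC(=O)c1cnc(NC(=O)[C@H](c2ccc(Cl)cc2)C(C)C)s1`: 98%

These three compounds share one core and differ only in the group on an aromatic carbon of that core. Each has been tested in a functional assay on CHO cells for agonist activity at Free fatty acid receptor 2 (Homo sapiens), read by cAMP accumulation; on this read-out lower numbers stand for smaller maximal responses and higher numbers for larger maximal responses. On these numbers compound 3 stands second highest of the three, but the differences are small: the step of a number 3 percentage points higher from compound 1 to compound 3 (within the scatter) and the step of a number 7 percentage points lower from compound 2 to compound 3 (within the scatter) both fall within the scatter, as does the step of a number 10 percentage points higher from compound 1 to compound 2 (within the scatter). All three compounds therefore reach about the same maximal response.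

Compound 4, `CC(C)[C@H](C(=O)Nc1ncc(C(N)=O)s1)c1ccc(Cl)cc1`, keeps the cyano and trifluoromethyl aside and starts from compound 3 instead. The change is amino in place of methoxy on a carbonyl carbon.

Going by the values given here, none of the measured steps touches this carbonyl carbon; they all concern the group on the aromatic carbon. What they show is that three quite different groups at that site left the maximal response within the scatter. The change to compound 4 is a different kind of change, so the expectation rests only on the general flatness of the data. The expected step of no change at the digits printed from compound 3 to compound 4 (within the scatter) is accordingly none beyond the scatter. For compound 4 the estimate is 98%, with a range from 84% to 112%.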

Compound 4, largest response reached (reported as efficacy), in percent of the reference or control that the assay uses: 59%
Compound 4: the middle estimate sits 39 percentage points above what was measured; measured number outside the range, below it.
By their numbers in this assay, from the lowest: compound 4; then compounds 1, 3 and 2 (each within the scatter of the next).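

In this assay, going by these compounds alone, this site proves less forgiving than the earlier compounds suggested: amino in place of methoxy on a carbonyl carbon gives a number 39 percentage points lower from compound 3 to compound 4 (beyond the scatter). The resulting carbamoyl group also stands apart from the two other groups on the aromatic carbon, with a number 46 percentage points lower from compound 2 to compound 4 (beyond the scatter) and a number 36 percentage points lower from compound 1 to compound 4 (beyond the scatter), so the similar responses of trifluoromethyl, cyano and methoxycarbonyl do not extend to every group placed there, and compound 4 gives the lowest maximal response of the four. Nothing available here explains this fall.

From the compounds shown here alone, it remains open whether the loss belongs to the hydrogen-bond donor that enters with the amino group or to some other difference between the two groups; methylamino and dimethylamino on the same carbonyl carbon, or a carboxylic acid in place of the ester, would help to separate these possibilities. The read-out also gives only the largest response reached, so these compounds leave open how the change affects the concentration needed to produce that response.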